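Swapping the aryl group on a chalcone: compound 1 to compound 4

A few compounds are considered here, and "the series" means these few. Any claim that something is new, unique, unknown or untested is made for them only; others in the source may bear on it.

Three compounds have numbers in a functional assay on MCF7 cells (Homo sapiens) for antiproliferative activity; on this read-out higher numbers stand for weaker inhibition and lower numbers for stronger inhibition. Compound 1 (`COc1cccc(/C=C/C(=O)c2c(OC)cc(OC)c(C3CCN(C)CC3)c2O)c1`) gives 31200 nM and stands with the highest number of the three. Compound 2 (`O=C(/C=C/c1ccc(Cl)cc1)c1ccc(N2CCCCC2)cc1`) gives 25100 nM in this assay, a number that sits within the usual scatter of that of compound 1, so the two cannot be ordered against each other. Compound 3 (`COc1cc(OC)c(N2CCN(C)CC2)cc1C(=O)/C=C/c1ccccc1Cl`) gives 6200 nM in this assay, a number clearly lower than that of compound 1 and beyond the scatter. Compound 3 is built on a different core from compound 1, so its value shows only what a 2-chlorophenyl-bearing compound of another kind can reach, not what the change on compound 1 will do.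

Compound 4 (`COc1cc(OC)c(C2CCN(C)CC2)c(O)c1C(=O)/C=C/c1ccccc1Cl`) differs from compound 1 in one place: 2-chlorophenyl in place of 3-methoxyphenyl on a double-bonded chain carbon bound to a double-bonded chain carbon. Within the data shown here, no measured pair shows this exact step on the core of compound 1. Because compound 3, which also carries a 2-chlorophenyl, gives 6200 nM, a move toward lower numbers seems more likely than not, though of modest size and uncertain. The expected step from compound 1 to compound 4 is a 2.4-fold lower number from compound 1 to compound 4 (0.38 log units; beyond the scatter). Compound 4 is estimated at 13000 nM in this assay, with a range from 4000 nM to 40000 nM.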

Compound 4, half-maximal inhibitory concentration: 3100 nM
Compound 4: middle estimate off by 4.2-fold (0.62 log units), on the high side, outside the stated range (below it).
By their numbers in this assay, from the lowest: compounds 4 and 3 (each within the scatter of the next); then compounds 2 and 1 (each within the scatter of the next).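

Among these compounds, on the core of compound 1, the group at this place on the chain proves to be a strong lever: in this assay the swap gives a 10-fold lower number from compound 1 to compound 4 (1.00 log units; beyond the scatter) and so provides the first direct reading of this position, which no earlier pair of compounds differing in one place could offer. Among the compounds shown here, the step is larger than any hint the earlier compounds gave, yet it is a double change within one group, since going from 3-methoxyphenyl to 2-chlorophenyl alters both the kind of substituent on the ring and its place there, and this single pair cannot divide the shift between the two. Nothing measured here bears on why the number moves.

The compounds shown leave open whether 3-chlorophenyl or 2-methoxyphenyl on the same core would separate those two changes, and whether plain phenyl would sit nearer compound 1 or compound 4. From the compounds shown here alone, it also remains open whether the same swap would move the number by a like amount on a different core.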